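Shifting the Fluorine on the Phenyl Group of Compound 1

A few compounds are considered here, and "the series" means these few. Any claim that something is new, unique, unknown or untested is made for them only; others in the source may bear on it.

Compound 1 `Cc1nc(N)sc1CCCN/C(N)=N/C(=O)NC(C)c1ccccc1F` was tested in a functional assay on Right cardiac atrium for agonist activity at histamine H2 receptor (Cavia porcellus), with a stated time of 30 min, in the presence of a further agent that is not named here (a lower number here means that less compound is needed, a higher number that more compound is needed for the effect), where compound 1 gives 12.3 nM. Its nearest neighbour by number is compound 2 `CCC(NC(=O)/N=C(\N)NCCCc1sc(N)nc1C)c1ccccc1`, and in this assay compound 2 gives 10.7 nM. Compound 1 has the higher of these two numbers, but the gap between them lies within the usual scatter, so the two compounds stand level rather than in any order.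

Compound 3 `Cc1nc(N)sc1CCCN/C(N)=N/C(=O)NC(C)c1cccc(F)c1` has not yet been measured. It differs from compound 1 in a single place: 3-fluorophenyl in place of 2-fluorophenyl on a saturated chain carbon bound to an amide-type nitrogen and a saturated chain carbon. The shared core and the chain to the amide-type nitrogen are untouched; only the arrangement of the fluorine on the phenyl group changes, from 2-fluorophenyl to 3-fluorophenyl. Among the compounds with values here, no measured pair in this set shows what such a move does, so there is no step to lean on.

On that basis compound 3 is expected to give about 12 nM in this assay, with a range from 4 nM to 35 nM. The step expected from compound 1 to compound 3, a 1.0-fold lower number from compound 1 to compound 3 (0.01 log units; within the scatter), is thus estimated to be none beyond the scatter, in either direction.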

Compound 3, half-maximal effective concentration: 26.3 nM
For compound 3 the middle estimate is 2.2-fold (0.34 log units) below the measured one; the range from low to high includes it.
By their numbers in this assay, from the lowest: compounds 2 and 1 (each within the scatter of the next); then compound 3.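

Within the data shown here, the move of the fluorine is the first change at this position that can be read in this assay. With the same atoms joined differently, 3-fluorophenyl in place of 2-fluorophenyl on a saturated chain carbon bound to an amide-type nitrogen and a saturated chain carbon gives a 2.1-fold higher number from compound 1 to compound 3 (0.33 log units; beyond the scatter), so the arrangement of the fluorine on the phenyl group is enough on its own to move the number beyond the usual scatter, though the step is modest. Nothing at hand gives a reason for this step, as no measurement of any property of these two groups bears on it.

The compounds shown leave open whether a chlorophenyl or a methoxyphenyl group on the same saturated chain carbon would give a number closer to that of compound 1 or to that of compound 3. They also leave open whether the same move of the fluorine would give a step of similar size if the methyl group on that carbon gave way to an ethyl group.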